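A few compounds are considered here, and "the series" means these few. Any claim that something is new, unique, unknown or untested is made for them only; others in the source may bear on it.

Compound 1 `Cc1ccc(/C=C2\CN(C(=S)SCc3cn(Cc4ccccc4F)nn3)C/C(=C\c3ccc(C)cc3)C2=O)cc1` was examined in a functional assay on PC-3 cells (Homo sapiens) for cytotoxicity, read by MTT assay, with a stated time of 24 h (a higher number here means a weaker inhibitor, a lower number a stronger inhibitor), and gave only a limit, with a reading of > 80000 nM. Compound 3 `COc1ccc(/C=C2\CN(Cc3cn(Cc4ccccc4F)nn3)C/C(=C\c3ccc(OC)cc3)C2=O)cc1` shares the same methylene-linked triazole and a fluoro group on an aromatic carbon, but differs from compound 1 in more than one place, and the difference between the two cores is not broken down here. In this assay compound 3 gives 39900 nM. Compound 2 `COc1ccc(/C=C2\CN(Cc3cn(Cc4ccccc4Cl)nn3)C/C(=C\c3ccc(OC)cc3)C2=O)cc1` carries chloro in place of fluoro on an aromatic carbon, and in this assay compound 2 gives 36300 nM. The step of a 1.1-fold lower number from compound 3 to compound 2 (0.04 log units; within the scatter) thus left the reading essentially unchanged.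

Compound 4 `Cc1ccc(/C=C2\CN(C(=S)SCc3cn(Cc4ccccc4Cl)nn3)C/C(=C\c3ccc(C)cc3)C2=O)cc1` is the chloro counterpart of compound 1: the change is chloro in place of fluoro on an aromatic carbon, the same change as that from compound 3 to compound 2, made at a place described in the same words. Because the measured step of a 1.1-fold lower number from compound 3 to compound 2 (0.04 log units; within the scatter) sits within the scatter, the same change is expected to move compound 4 little from compound 1. Since compound 1 sits at the limit (the limit of > 80000 nM in this assay, at which 1 of the 3 values shown sits), compound 4 is expected to remain near that limit as well, an expected step that the limit leaves unreadable from compound 1 to compound 4. In this assay compound 4 is therefore estimated at 90000 nM, with an expected range from 45000 nM to 200000 nM, and a substantial chance that only a limit is reported.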

Compound 4, half-maximal inhibitory concentration: > 80000 nM
Compound 4 ended at the assay's limit; the forecaster's own chance of this, stated with the estimate: 70%; the middle value is on the limit's open side.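

Compound 1 and compound 4 both stop at a limit of the assay in this assay, and no step between them can be read: the limit of > 80000 nM in this assay, at which 2 of the 4 values shown sit.

The compounds shown leave open how far compound 1 and compound 4 lie past that limit, and whether chloro in place of fluoro on an aromatic carbon behaves on their core as it does on the core shared by compound 3 and compound 2.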